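The source may report more compounds than this note shows. Statements on the series, on what has been measured and on what is new or still open speak of the compounds shown alone.

Measured so far, in a functional assay on DU-145 cells (Homo sapiens) for inhibition, read by trypan blue exclusion, with a stated time of 96 h; a higher number here means a weaker inhibitor of growth, a lower number a stronger inhibitor of growth:
compound 1, `COc1ccccc1/C=C(/SCc1ccc(Cl)cc1)C(=O)c1ccc(Cl)cc1`, gives 1000 nM;
compound 2, `Cc1ccc(/C=C(/SCc2ccc(Cl)cc2)C(=O)c2ccc(Cl)cc2)s1`, gives 50000 nM;
compound 3, `COc1ccccc1/C=C(/SCc1ccc(C)cc1)C(=O)c1ccc(Cl)cc1`, gives 10000 nM.

Compound 4, `Cc1ccc(CS/C(=C/c2ccc(C)s2)C(=O)c2ccc(Cl)cc2)cc1`, is not yet measured. It differs from compound 3 by 5-methylthiophen-2-yl in place of 2-methoxyphenyl on a double-bonded chain carbon bound to a double-bonded chain carbon. The same change has already been made once, from compound 1 to compound 2, where it is 5-methylthiophen-2-yl in place of 2-methoxyphenyl on a double-bonded chain carbon bound to a double-bonded chain carbon and gave a 50-fold higher number from compound 1 to compound 2 (1.70 log units; beyond the scatter). The two cores differ by methyl in place of chloro on an aromatic carbon, a change that gave a 10-fold higher number from compound 1 to compound 3 (1.00 log units; beyond the scatter). For the measured compounds named here, because the earlier step was a 50-fold higher number from compound 1 to compound 2 (1.70 log units; beyond the scatter) and the change is the same, the step from compound 3 to compound 4 is expected to be of similar size, a 30-fold higher number from compound 3 to compound 4 (1.48 log units; beyond the scatter), though only one prior example supports this. Compound 4 is therefore estimated at 300000 nM, expected between 80000 nM and 1500000 nM.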

Compound 4, concentration for 50% growth inhibition: 50000 nM
Compound 4: the middle estimate sits 6.0-fold (0.78 log units) above what was measured, outside the stated range (below it).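

Putting 5-methylthiophen-2-yl in place of 2-methoxyphenyl gives a 5.0-fold higher number from compound 3 to compound 4 (0.70 log units; beyond the scatter) in this assay, so the direction seen on the core of compound 1 carries over, but the size does not: the same change on two cores in this assay, a 50-fold higher number (1.70 log units; beyond the scatter) from compound 1 to compound 2 and a 5.0-fold higher number (0.70 log units; beyond the scatter) from compound 3 to compound 4, 10-fold (1.00 log units) apart, beyond the scatter of two such steps. Methyl in place of chloro likewise behaves differently on the two cores, giving no change at the digits printed from compound 2 to compound 4 (within the scatter): the same change on two cores in this assay, a 10-fold higher number (1.00 log units; beyond the scatter) from compound 1 to compound 3 and no change at the digits printed (within the scatter) from compound 2 to compound 4, 10-fold (1.00 log units) apart, beyond the scatter of two such steps. For the compounds shown here, this shows that in these four compounds the two changes do not simply add up, but with only two cores it does not show why, or how the swap would behave on a third core.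

The compounds shown leave open whether a plain phenyl or a pyridine ring in that place would follow the same pattern. They also leave open what a bromo or a trifluoromethyl group would do in place of the chloro.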